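From acetyl to amino on the shared core

The source may report more compounds than this note shows. Statements on the series, on what has been measured and on what is new or still open speak of the compounds shown alone.

Measured in an ADME assay on MDCK cells (Canis lupus familiaris) for cytotoxicity, read by MTT assay, with a stated time of 24 h; a lower number here means that less compound is tolerated, a higher number that more compound is tolerated:
Compound 1 `N#CCCN(Cc1cccs1)S(=O)(=O)c1ccc(Br)cc1` gives > 173000 nM, a limit.
Compound 2 `CC(=O)c1ccc(S(=O)(=O)N(CCC#N)Cc2cccs2)cc1` gives > 191000 nM, a limit.

Compound 2 stands only at a limit of > 191000 nM and has no exact number. Among the measured compounds shown here, the one other measured compound also gives only a limit, so neither compound supplies an exact value for comparison.

The next compound, compound 3 `N#CCCN(Cc1cccs1)S(=O)(=O)c1ccc(N)cc1`, carries amino in place of acetyl on an aromatic carbon, para to a large group: amino in place of acetyl on an aromatic carbon. For the measured compounds named here, the one measured step that bears on this change also involves the acetyl group on an aromatic carbon, which there takes the place of bromo: a step that the two limits leave unreadable from compound 1 to compound 2. That step has no readable size and shows no direction, so it offers no measured basis for expecting a shift. In this assay, no step beyond the scatter is therefore expected, in either direction. The step expected on this basis is a number no higher from compound 2 to compound 3 (the limit leaves the size open). Compound 3 is estimated at 190000 nM, with an expected range of 90000 nM to 380000 nM.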

Compound 3, half-maximal cytotoxic concentration: > 207000 nM
Compound 3: a limit, no number; the forecaster's own chance of this, stated with the estimate: 70%; at least 1.0-fold (0.03 log units) between middle value and limit.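

Compound 3 gives > 207000 nM, which is a limit and not a number. Among the compounds shown here, compound 1 and compound 2 also stand only at limits, so no step among the three can be read. The compounds shown leave open where each half-maximal cytotoxic concentration lies, and whether bromo, acetyl or amino on the aromatic carbon makes any difference to it.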